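The compounds below may be only part of what the source reports. "The series", "measured", "known", "first", "only" and "open" are said of these compounds alone.

Measured compounds:
Compound 1 `CC1(C)CC(NC(=S)Nc2cccc([N+](=O)[O-])c2)c2cc(Br)ccc2O1` — 5000 nM
Compound 2 `CC1(C)CC(NC(=S)Nc2cccc(Cl)c2)c2cc(Br)ccc2O1` — 7000 nM
Compound 3 `COc1cccc(NC(=S)NC2CC(C)(C)Oc3ccc(Br)cc32)c1` — "not determined" (no result reported)

In a functional assay on B16-F10 cells (Mus musculus) for inhibition, read by MTT assay, with a stated time of 72 h (a higher number here means a weaker inhibitor, a lower number a stronger inhibitor), compound 1 gives 5000 nM, and compound 2 gives 7000 nM. Compound 3 carries no number in this assay. Among the measured compounds shown here, compound 1 therefore stands alongside compound 2 as one of only two measured values, and the change from one to the other, a 1.4-fold higher number from compound 1 to compound 2 (0.15 log units; within the scatter), does not separate them. For the measured compounds named here, that step concerns the substituent on the aryl thiourea end of the molecule and is the only measured step in the set.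

Compound 4 `CC1(C)CC(NC(=S)Nc2cccc([N+](=O)[O-])c2)c2cc(Cl)ccc2O1` has not been measured. It differs from compound 1 as follows: chloro in place of bromo on an aromatic carbon. Going by the values given here, the one measured step does not touch this position, so nothing in the data speaks directly to a change at the fused ring of the core. Among the compounds with values here, with no comparable step available and the single known step lying within the scatter, the step of no change at the digits printed from compound 1 to compound 4 (within the scatter) is expected to be small, in no particular direction, and not beyond the scatter. Compound 4 is therefore estimated to give 5000 nM in this assay, with a plausible range from 2500 nM to 10000 nM.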

Compound 4, half-maximal inhibitory concentration: 6000 nM
Compound 4: the middle estimate sits 1.2-fold (0.08 log units) below what was measured; measured number inside the range.
By their numbers in this assay, from the lowest: compounds 1, 4 and 2 (each within the scatter of the next).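

In this assay, chloro in place of bromo on the aromatic carbon of the fused system gives a 1.2-fold higher number from compound 1 to compound 4 (0.08 log units; within the scatter) and thus does not separate the two compounds. Among the compounds shown here, the earlier measured step, a 1.4-fold higher number from compound 1 to compound 2 (0.15 log units; within the scatter), lay on the aryl thiourea end of the molecule, so this is the first reading from the core itself, and with the nitro group held constant, this exchange of one halogen for the other leaves the values within the scatter. No measurement is available here that would explain the size of this step.

With only bromo and chloro shown at this position, it remains open what a much different group there, such as an amine, a carboxylic acid or a longer alkyl chain, would give in this assay. It also remains open whether the same exchange of bromo for chloro would give a similar step when the aromatic ring at the thiourea end carries chloro rather than nitro, as no such pair is shown.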